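Amide to Ester on the Shared Core: Expecting Compound 4

The compounds below may be only part of what the source reports. "The series", "measured", "known", "first", "only" and "open" are said of these compounds alone.

Compound 1 `O=C(NCc1ccccc1)c1cn(-c2ccccc2)nc1-c1cccnc1` reaches only the limit > 100000 nM in a functional assay on MDA-MB-231 cells (Homo sapiens) for cytotoxicity, read by MTT assay, with a stated time of 48 h; a lower number here means a stronger inhibitor, a higher number a weaker inhibitor.
Compound 2 `CC(C)c1cccc(OC(=O)c2cn(-c3ccccc3)nc2-c2cccnc2)c1` likewise reaches only the limit > 100000 nM in this assay.
Compound 3 `O=C(NCc1ccccc1)c1cn(-c2ccccc2)nc1-c1ccncc1` too reaches only the limit > 100000 nM in this assay.

Compound 3 therefore stands nowhere above the floor of what was measured: its value is a limit, not a number, and the same holds for the other two compounds. Among the compounds with values here, the one measured step, a step that the two limits leave unreadable from compound 1 to compound 3, cannot be read in size because both of its compounds sit at the limit of > 100000 nM in this assay, at which 3 of the 3 values shown sit. Compound 1 and compound 2 differ in the group on the carbonyl carbon, yet both show only a limit, so nothing can be said about that change either.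

Compound 4 `CCc1ccc(OC(=O)c2cn(-c3ccccc3)nc2-c2ccncc2)cc1` is reached from compound 3 by 4-ethylphenoxy in place of benzylamino on a carbonyl carbon. Within the data shown here, no measured step bears on this change with a readable size; the only related evidence is that compound 2, which also carries an ester on the carbonyl carbon, sits at the limit. The expected step of a number no higher from compound 3 to compound 4 (the limit leaves the size open) is therefore none that could be told apart from the scatter. Compound 4 is expected at 100000 nM, within a range from 30000 nM to 300000 nM, most likely again as a limit.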

Compound 4, half-maximal inhibitory concentration: > 100000 nM
Compound 4: only a limit was reported; the forecaster's own chance of this, stated with the estimate: 80%; the middle value sits exactly at the limit.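

No size can be read for the change from compound 3 to compound 4, since both compounds give only a limit and not a number: the limit of > 100000 nM in this assay, at which 4 of the 4 values shown sit.

The compounds shown leave open whether any group on the shared core gives a measurable value in this assay, and what placing 4-ethylphenoxy in place of benzylamino does to cytotoxicity.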